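Swapping a pyrimidinyl group for a furoyl group on the piperazine

This account rests on a few compounds, and the source may have more. Where it says the series, first, only, none or still open, it means among the compounds named here.

Measured compounds:
compound 1, `CCOC(=O)N1CCN(C(=S)SC(=S)N(C)C)CC1`, 530000 nM in an ADME assay on HeLa cells (Homo sapiens) for cytotoxicity, read by MTT assay, with a stated time of 24 h; on this read-out higher numbers stand for weaker inhibition and lower numbers for stronger inhibition
compound 2, `CN(C)C(=S)SC(=S)N1CCN(c2ccccc2)CC1`, 1610000 nM
compound 3, `CN(C)C(=S)SC(=S)N1CCN(c2ncccn2)CC1`, > 5000000 nM

Compound 3 sits at the weak end of the three measured compounds. For compound 3 this assay reports only a limit, > 5000000 nM, which is one of the values described by the limit of > 5000000 nM in this assay, at which 1 of the 3 values shown sits. The steps leading to it all go in the same direction: a 3.0-fold higher number from compound 1 to compound 2 (0.48 log units; beyond the scatter), an at least 9.4-fold higher number from compound 1 to compound 3 (0.97 log units; beyond the scatter) and an at least 3.1-fold higher number from compound 2 to compound 3 (0.49 log units; beyond the scatter), so replacing the ethoxycarbonyl group on the ring nitrogen by an aromatic ring has given weaker inhibition in each case.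

Compound 4, `CN(C)C(=S)SC(=S)N1CCN(C(=O)c2ccco2)CC1`, has not yet been measured. Its difference from compound 3 is (furan-2-yl)carbonyl in place of pyrimidin-2-yl on an amine nitrogen in a ring. The entering group is, like the ethoxycarbonyl of compound 1, a carbonyl attached to the ring nitrogen, rather than an aromatic ring attached directly. The step that bears most on this change is therefore the reverse of an at least 9.4-fold higher number from compound 1 to compound 3 (0.97 log units; beyond the scatter), which would point back toward the value of compound 1. Because compound 3 has only a limit, the size of the expected step is uncertain, but a lower number than compound 3 is expected, with an at least 5.5-fold lower number from compound 3 to compound 4 (0.74 log units; beyond the scatter).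

Compound 4 is therefore estimated at 900000 nM, with a range from 300000 nM to 3500000 nM.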

Compound 4, half-maximal inhibitory concentration: 2380000 nM
For compound 4 the middle estimate is 2.6-fold (0.42 log units) below the measured one, and the stated range covers the measured number.
By their numbers in this assay, from the lowest: compound 1; then compounds 2 and 4 (each within the scatter of the next). At a limit, above all of these: compound 3.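

In this assay, (furan-2-yl)carbonyl on the ring nitrogen gives an at least 2.1-fold lower number from compound 3 to compound 4 (0.32 log units; beyond the scatter), which shows that this position still responds when pyrimidin-2-yl leaves, though the size of the step is only a minimum because compound 3 carries a limit of the assay: the limit of > 5000000 nM in this assay, at which 1 of the 4 values shown sits. A carbonyl on the ring nitrogen is not enough on its own to match compound 1: with the carbonyl kept, furan-2-yl in place of ethoxy gives a 4.5-fold higher number from compound 1 to compound 4 (0.65 log units; beyond the scatter). Nor does the carbonyl set the furan-bearing compound apart from the phenyl one, since (furan-2-yl)carbonyl in place of phenyl gives a 1.5-fold higher number from compound 2 to compound 4 (0.17 log units; within the scatter), so on this read-out these two groups cannot be told apart.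

The compounds shown leave open whether the ethoxy group itself matters, which a methoxy group or a longer butoxy chain on the same carbonyl would help to test. They also leave open whether any carbonyl is needed at this position, which a plain ethyl chain or an acetyl group on the ring nitrogen would help to settle.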